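Nitrile for methoxy on the biaryl tail of a furoic acid

The compounds below may be only part of what the source reports. "The series", "measured", "known", "first", "only" and "open" are said of these compounds alone.

Measured so far:
compound 1 `CC(=O)c1ccc(-c2ccc(OCc3cc(C(=O)O)oc3C)cc2)cc1` with 150 nM
compound 2 `COc1ccccc1-c1ccc(OCc2cc(C(=O)O)oc2C)cc1` with 1600 nM

In an assay on cells for displacement of a labelled ligand from prostaglandin E2 receptor EP4 subtype (Homo sapiens), read by scintillation counting (on this read-out higher numbers stand for weaker inhibition and lower numbers for stronger inhibition), compound 2 gives 1600 nM, the highest of the two numbers; compound 1 gives 150 nM, a gap that lies beyond the usual scatter. Compound 3 `Cc1oc(C(=O)O)cc1COc1ccc(-c2ccc(C#N)cc2)cc1` is not yet measured. It differs from compound 2 in one place: 4-cyanophenyl in place of 2-methoxyphenyl on an aromatic carbon, para to a large group. Among the measured compounds shown here, no measured pair shows this change, so the expected step of a 6.4-fold lower number from compound 2 to compound 3 (0.81 log units; beyond the scatter) rests on the two values alone and is uncertain; a step towards stronger inhibition is expected. The estimate for compound 3 is 250 nM, between 60 nM and 1000 nM.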

Compound 3, inhibition constant: 1500 nM
Estimate against measurement, compound 3: 6.0-fold (0.78 log units) below, and the stated range ends below it.
By their numbers in this assay, from the lowest: compound 1; then compounds 3 and 2 (each within the scatter of the next).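

In this assay, 4-cyanophenyl in place of 2-methoxyphenyl gives a 1.1-fold lower number from compound 2 to compound 3 (0.03 log units; within the scatter) and so leaves these two tails level. The group on that outer ring still counts: cyano in place of acetyl gives a 10-fold higher number from compound 1 to compound 3 (1.00 log units; beyond the scatter) and shows that the nitrile does not keep the stronger inhibition of compound 1. Nothing measured here explains either step.

A 4-methoxyphenyl tail would separate the choice of group from its place on the ring. A primary amide or a methyl ester in place of acetyl would test whether that stronger inhibition extends beyond acetyl.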